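Swapping hydrogen for fluoro on the aniline-side ring

A few compounds are considered here, and "the series" means these few. Any claim that something is new, unique, unknown or untested is made for them only; others in the source may bear on it.

Compound 1 `COc1ccccc1-c1csc2cnc(Nc3ccc(C(=O)NC4CCNCC4)cc3C)nc12` in a functional assay on A549 cells (Homo sapiens) for inhibition, read by MTT assay, with a stated time of 72 h; on this read-out lower numbers stand for stronger inhibition and higher numbers for weaker inhibition: 3420 nM
Compound 2 `COc1ccccc1-c1csc2cnc(Nc3ccc(C(=O)NC4CCNCC4)cc3)nc12` in this assay: 360 nM

Compound 2, at 360 nM, holds the lower of the two numbers. Compound 3 `COc1ccccc1-c1csc2cnc(Nc3ccc(C(=O)NC4CCNCC4)cc3F)nc12` differs from it by one change: fluoro in place of hydrogen on an aromatic carbon. Among the measured compounds shown here, only one measured step bears on this: a 9.5-fold lower number from compound 1 to compound 2 (0.98 log units; beyond the scatter), where hydrogen took the place of methyl at that same carbon. Fluoro is not methyl, so this single step suggests a direction more than a size. A smaller rise than that one is expected in this assay. The estimated step is a 1.9-fold higher number from compound 2 to compound 3 (0.29 log units; within the scatter). For compound 3 the estimated value is 700 nM, with an expected range of 250 nM to 2200 nM.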

Compound 3, half-maximal inhibitory concentration: 2750 nM
For compound 3 the middle estimate is 3.9-fold (0.59 log units) below the measured one; measured number outside the range, above it.
By their numbers in this assay, from the lowest: compound 2; then compounds 3 and 1 (each within the scatter of the next).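

In this assay the step of a 7.6-fold higher number from compound 2 to compound 3 (0.88 log units; beyond the scatter) means that the low number of compound 2 is lost with fluoro as well as with methyl at this carbon, ortho to a large group. Fluoro and methyl cannot be told apart here, with a 1.2-fold lower number from compound 1 to compound 3 (0.09 log units; within the scatter) as the step between them; of the three, only hydrogen gives the low number.

From the compounds shown here alone, whether chloro, methoxy or an amine at this carbon would also go with a high number stays open. No measurement at hand offers an explanation for these steps.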